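Cytotoxicity notes: aryl group at the core

The source may hold more compounds than are shown below. What is called first, only, known or untested is meant among the compounds shown, and "the series" means these compounds.

Measured compounds:
- compound 1 `Cc1ccc(-c2cnc(Nc3ccc(C#N)cc3)nc2Oc2c(C)cc(C#N)cc2C)cc1`: 26100 nM
- compound 2 `Cc1cc(C#N)cc(C)c1Oc1nc(Nc2ccc(C#N)cc2)ncc1-c1ccc(F)cc1`: 42700 nM
- compound 3 `Cc1cc(C#N)cc(C)c1Oc1nc(Nc2ccc(C#N)cc2)ncc1-c1ccc2ccccc2c1`: 8460 nM

All three were tested in an ADME assay on MT4 cells (Homo sapiens) for cytotoxicity, read by MTT assay, with a stated time of 5 days; a higher number here means that more compound is tolerated, a lower number that less compound is tolerated. Compound 3 gives the lowest number of the three, so it is the least tolerated: the step of a 3.1-fold lower number from compound 1 to compound 3 (0.49 log units; beyond the scatter) and the step of a 5.0-fold lower number from compound 2 to compound 3 (0.70 log units; beyond the scatter) both lie beyond the scatter, while the step of a 1.6-fold higher number from compound 1 to compound 2 (0.21 log units; within the scatter) does not.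

Compound 4 `Cc1cc(C#N)cc(C)c1Oc1nc(Nc2ccc(C#N)cc2)ncc1-c1ccncc1` is not yet measured. It differs from compound 3 in one place: pyridin-4-yl in place of naphthalen-2-yl on an aromatic carbon. Among the measured compounds shown here, the steps that bear on this are those leading to compound 3, in which a two-ring group replaced a single six-membered ring and the number fell beyond the scatter. Compound 4 reverses that direction, back to a single six-membered ring, here one carrying a ring nitrogen. The expectation is therefore a higher number in this assay for compound 4 than for compound 3, of a size comparable to the return towards compound 1 and compound 2, with the estimated step being a 4.1-fold higher number from compound 3 to compound 4 (0.62 log units; beyond the scatter). Compound 4 is thus expected to give about 35000 nM, within a range from 12000 nM to 100000 nM.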

Compound 4, half-maximal cytotoxic concentration: 28000 nM
For compound 4 the middle estimate is 1.3-fold (0.10 log units) above the measured one, within the range that was stated.
By their numbers in this assay, from the lowest: compound 3; then compounds 1, 4 and 2 (each within the scatter of the next).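

At this position on the shared core, a ring nitrogen in a single six-membered aromatic ring does not separate the result from the carbon-only single rings in this assay: the comparison with the 4-methylphenyl group gives a 1.1-fold higher number from compound 1 to compound 4 (0.03 log units; within the scatter) and the comparison with the 4-fluorophenyl group gives a 1.5-fold lower number from compound 2 to compound 4 (0.18 log units; within the scatter) and both are within the scatter. The naphthalen-2-yl group now stands apart from all three single rings, and the change to pyridin-4-yl, which leaves two six-membered aromatic rings of carbon only and brings in one ring with a hydrogen-bond acceptor, gives a 3.3-fold higher number from compound 3 to compound 4 (0.52 log units; beyond the scatter) as a step beyond the scatter. No measurement is at hand that accounts for the low number of the naphthalen-2-yl compound or for the absence of a difference among the single rings.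

Whether a second ring alone goes with the lower number remains open, since a two-ring group carrying a ring nitrogen, such as quinolin-3-yl, does not appear among these compounds. Also open, from the compounds shown here alone, is how this position responds to a single ring bearing an amine or a carboxylic acid, or to a saturated ring such as morpholine in place of the aromatic groups.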